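Swapping the chloromethyl group on compound 2

The source may report more compounds than this note shows. Statements on the series, on what has been measured and on what is new or still open speak of the compounds shown alone.

Measured in a functional assay on JeKo-1 cells (Homo sapiens) for inhibition, read by luminescence and CellTiter-Glo, with a stated time of 72 h; a higher number here means a weaker inhibitor, a lower number a stronger inhibitor:
Compound 1 `O=C(CCl)N1CCCC(n2nc(-c3ccc(Oc4ccccc4)cc3)cc2CO)C1`: 7800 nM
Compound 2 `O=C(O)c1cc(-c2ccc(Oc3ccccc3)cc2)nn1C1CCCN(C(=O)CCl)C1`: 3600 nM
Compound 3 `C/C=C/C(=O)Nc1ccc(Cn2nc(-c3ccc(Oc4ccccc4)cc3)cc2CO)cc1`: > 60000 nM (a limit of the assay)

Compound 2 has the lower of the two actual numbers, as shown by a 2.2-fold lower number from compound 1 to compound 2 (0.34 log units; beyond the scatter). That modest step lies elsewhere in the molecule, so it does not directly inform the next change. Compound 4 `C/C=C/C(=O)N1CCCC(n2nc(-c3ccc(Oc4ccccc4)cc3)cc2C(=O)O)C1` has prop-1-en-1-yl in place of chloromethyl on a carbonyl carbon. Among the measured compounds shown here, no measured step makes this swap. Compound 3 has a different core but the same prop-1-en-1-yl group on a carbonyl carbon, and its > 60000 nM is a limit of the assay. A weaker inhibitor is therefore expected in this assay, with an estimated 5.6-fold higher number from compound 2 to compound 4 (0.74 log units; beyond the scatter). For compound 4 the estimate is 20000 nM, within a range of 6000 nM to 60000 nM.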

Compound 4, half-maximal inhibitory concentration: > 60000 nM
Compound 4: a limit, no number (the forecaster's own chance of this, stated with the estimate: 30%); at least 3.0-fold (0.47 log units) between middle value and limit.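

On the carbonyl carbon whose other neighbour is the amide-type nitrogen in a ring, prop-1-en-1-yl in place of chloromethyl gives an at least 16-fold higher number from compound 2 to compound 4 (1.22 log units; beyond the scatter) in this assay. Among the compounds shown here, this is the first direct reading at this position, and the large step shows that the group on the carbonyl carbon matters far more here than the earlier carboxy for hydroxymethyl change did. The value of compound 4 is a limit, not a number, so the step's full size stays unknown: the limit of > 60000 nM in this assay, at which 2 of the 4 values shown sit.

Still open, going by these compounds, is whether chloromethyl itself is needed. The compounds shown do not tell how bromomethyl, ethenyl or a longer chain carrying an amine would fare on this carbonyl carbon.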